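Phosphorus configuration and acyl group in a prodrug series

The source may hold more compounds than are shown below. What is called first, only, known or untested is meant among the compounds shown, and "the series" means these compounds.

Measured so far:
- compound 1 `COC(=O)CCNC(=O)[C@@H]1O[P@](=O)(OCOC(=O)c2ccnn2C)OCC1(C)C`: < 0.16 h
- compound 2 `COC(=O)CCNC(=O)[C@@H]1O[P@@](=O)(OCOC(=O)c2ccnn2C)OCC1(C)C`: > 1 h
- compound 3 `CCOC(=O)CCNC(=O)[C@@H]1O[P@@](=O)(OCOC(=O)C(C)(C)C)OCC1(C)C`: 0.28 h

In an ADME assay on blood (Homo sapiens) for pharmacokinetics (a lower number here means that the compound disappears faster, a higher number that the compound lasts longer), compound 1 gives < 0.16 h, which is a limit of the assay and not a number. Compound 2 gives > 1 h in this assay, again a limit and not a number. Compound 3 gives 0.28 h in this assay. Among the compounds with values here, the one step between measured compounds, an at least 6.2-fold higher number from compound 1 to compound 2 (0.79 log units; beyond the scatter), rests on the two configurations at phosphorus; because of the fact that compounds 1 and 2 differ only in the configuration as drawn the whole of that step is carried by the drawn configuration, with its size bounded by the limit of < 0.16 h in this assay, at which 1 of the 3 values shown sits, and (the limit of > 1 h in this assay, at which 1 of the 3 values shown sits). Compound 2 thus stands at the upper edge of the numbers shown, as a limit.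

Compound 4 `COC(=O)CCNC(=O)[C@@H]1O[P@@](=O)(OCOC(=O)c2scnc2C(C)(C)C)OCC1(C)C` keeps the configuration of compound 2 and differs by 4-(tert-butyl)-1,3-thiazol-5-yl in place of 1-methyl-1H-pyrazol-5-yl on a carbonyl carbon. Within the data shown here, no measured step touches this acyl group, so no direction beyond the scatter is expected in this assay; the estimated step is a step that the limit leaves unreadable from compound 2 to compound 4. Compound 4 is therefore expected at 1.5 h, within 0.5 h to 4 h.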

Compound 4, half-life: > 1 h
Compound 4 was reported as a limit (the forecaster's own chance of this, stated with the estimate: 40%); the middle value does not contradict the limit.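

Compound 2 and compound 4 are both reported as limits in this assay, and the step between them cannot be read. Left open is whether 4-(tert-butyl)-1,3-thiazol-5-yl in place of 1-methyl-1H-pyrazol-5-yl on a carbonyl carbon changes the half-life at all, and in which direction.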